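From an Anilide to a Piperidine Amide

This account rests on a few compounds, and the source may have more. Where it says the series, first, only, none or still open, it means among the compounds named here.

Two compounds share one core and differ only on the amide-type nitrogen. Compound 1, `CN1C[C@H](C(=O)Nc2cccc(F)c2)[C@@H](c2ccc(/C=C/C(=O)Nc3ccccc3N)cc2)C1`, carries 3-fluorophenyl there, and in an in vitro ADME assay on microsomes from liver (Homo sapiens) for pharmacokinetics, read by LC-MS, with a stated time of 10 min, tested at 1 uM (a higher number here means faster removal of the compound, a lower number slower removal), compound 1 gives 6 mL/min/kg. Compound 2, `CN1C[C@H](C(=O)Nc2ccccc2F)[C@@H](c2ccc(/C=C/C(=O)Nc3ccccc3N)cc2)C1`, carries 2-fluorophenyl instead, and in this assay compound 2 gives 10 mL/min/kg. Of the two numbers measured, that of compound 2 is the one standing higher, yet the step of a 1.7-fold higher number from compound 1 to compound 2 (0.22 log units; within the scatter) is within the scatter, so no order can be read from these two values.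

Compound 3, `CN1C[C@H](C(=O)N2CCCCC2)[C@@H](c2ccc(/C=C/C(=O)Nc3ccccc3N)cc2)C1`, is the next compound. It differs from compound 2 in one place: piperidin-1-yl in place of (2-fluorophenyl)amino on a carbonyl carbon. Within the data shown here, the only measured step, a 1.7-fold higher number from compound 1 to compound 2 (0.22 log units; within the scatter), concerns the fluorophenyl group alone and does not speak to the exchange of (2-fluorophenyl)amino for piperidin-1-yl on the carbonyl carbon. Among the measured compounds shown here, with no step that bears on this change, the data give no direction, and the expected step in this assay is a 1.1-fold higher number from compound 2 to compound 3 (0.04 log units; within the scatter), nothing beyond the scatter. Compound 3 is therefore estimated at 11 mL/min/kg, with a range from 4 mL/min/kg to 30 mL/min/kg.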

Compound 3, clearance: 9 mL/min/kg
The estimate for compound 3 lay 1.2-fold (0.09 log units) above the measured number; the range from low to high includes it.
By their numbers in this assay, from the lowest: compounds 1, 3 and 2 (each within the scatter of the next).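

The position on the carbonyl carbon accepts more than a fluorinated anilide: piperidin-1-yl takes out the aromatic ring of carbon only and the hydrogen-bond donor of (2-fluorophenyl)amino, yet in this assay the exchange gives a 1.1-fold lower number from compound 2 to compound 3 (0.05 log units; within the scatter) and, against the other anilide, a 1.5-fold higher number from compound 1 to compound 3 (0.18 log units; within the scatter) as well. The earlier pair varied only the fluorophenyl group, whereas these steps show that replacing the whole (2-fluorophenyl)carbamoyl group with (piperidin-1-yl)carbonyl leaves compound 3 within the scatter of both anilides, so the three compounds cannot be placed in any order. No measurement at hand offers an explanation for this result.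

The three compounds leave open whether the same holds for a morpholin-4-yl ring, a pyrrolidin-1-yl ring or an open-chain dimethylamino group on this carbonyl carbon, or for a carboxylic acid in place of the amide. They also say nothing of changes elsewhere on the shared core, since the 2-aminophenyl amide and the methyl group stay the same throughout.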